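Adding a Second Chloro to the Shared Core

The source may hold more compounds than are shown below. What is called first, only, known or untested is meant among the compounds shown, and "the series" means these compounds.

compound 1, `ClCc1cccc(Cn2cnc3ncnc(Cl)c32)c1`: 4070 nM
compound 2, `ClCc1ccc(Cn2cnc3nc(Cl)nc(Cl)c32)cc1`: 2750 nM

In a functional assay on CAKI-1 cells (Homo sapiens) for cytotoxicity, read by sulforhodamine B assay, with a stated time of 48 h (on this read-out lower numbers stand for stronger inhibition of growth and higher numbers for weaker inhibition of growth), compound 1 gives 4070 nM, the highest of the two numbers shown. Compound 2 gives 2750 nM, a number that lies within the usual scatter of the first, so the two cannot be told apart. Compound 3, `ClCc1cccc(Cn2cnc3nc(Cl)nc(Cl)c32)c1`, has not yet been measured. It differs from compound 1 by chloro in place of hydrogen on an aromatic carbon. Within the data shown here, no single-change pair among the measured compounds is available, so no measured step guides the expectation directly; what can be said is that compound 2, which also carries this chloro on its core, gives a number close to compound 1. The step of a 1.3-fold lower number from compound 1 to compound 3 (0.10 log units; within the scatter) is therefore expected to be small, in no clear direction, and within the scatter. The estimate for compound 3 is 3200 nM, with a range from 1300 nM to 8000 nM.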

Compound 3, concentration for total growth inhibition: 3460 nM
The estimate for compound 3 lay 1.1-fold (0.03 log units) below the measured number, within the range that was stated.
By their numbers in this assay, from the lowest: compounds 2, 3 and 1 (each within the scatter of the next).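

This is the first pair among the compounds shown that differs in one place only, so the chloro on the aromatic carbon between two ring nitrogen atoms can now be read by itself. In this assay the step is a 1.2-fold lower number from compound 1 to compound 3 (0.07 log units; within the scatter) and stays within the scatter, so chloro in place of hydrogen at this position gives a number that cannot be told apart from that of the parent compound. Nothing available explains this result.

From the compounds shown here alone, whether a larger or different group at this same position, such as an amine or a methoxy group, would give a clearly different number remains open. Also open, going by these compounds, is whether a hydroxymethyl group in place of the chloromethyl group would shift the number.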